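Swapping the amide aryl group on a thiadiazole scaffold

The compounds below may be only part of what the source reports. "The series", "measured", "known", "first", "only" and "open" are said of these compounds alone.

Compound 2 `Cc1ccc(NC(=O)CSc2snnc2-c2ccccc2)c(Br)c1` carries a 2-bromo-4-methylphenyl group on the amide nitrogen of a shared core. In an ADME assay on MT4 cells (Homo sapiens) for cytotoxicity (a higher number here means that more compound is tolerated, a lower number that less compound is tolerated), compound 2 shows only a limit, > 297000 nM, rather than a number. Its neighbour, compound 1 `O=C(CSc1snnc1-c1ccccc1)Nc1ccccc1F`, bears a 2-fluorophenyl group in the same place. In this assay compound 1 likewise reaches only a limit, > 361000 nM. Within the data shown here, the one measured step, a step that the two limits leave unreadable from compound 1 to compound 2, therefore cannot be sized, because the limit of > 297000 nM in this assay, at which 1 of the 2 values shown sits, and the limit of > 361000 nM in this assay, at which 1 of the 2 values shown sits, are both limits and not numbers.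

Compound 3 `O=C(CSc1snnc1-c1ccccc1)Nc1ccccc1Cl` differs from compound 2 by a single change, (2-chlorophenyl in place of 2-bromo-4-methylphenyl on an amide-type nitrogen). Among the measured compounds shown here, no measured step bears directly on this swap, so the expectation rests only on the two limits, which show no toxicity detectable within the tested range for either compound. Compound 3 is therefore expected to sit at a similar limit, with a step from compound 2 of a step that the limit leaves unreadable from compound 2 to compound 3 that is essentially none beyond the scatter. The estimated value for compound 3 in this assay is 350000 nM, with a range from 150000 nM to 900000 nM.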

Compound 3, half-maximal cytotoxic concentration: > 345000 nM
Compound 3 was reported as a limit (the forecaster's own chance of this, stated with the estimate: 85%); the middle value does not contradict the limit.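

In this assay compound 3 gives > 345000 nM, which is a limit and not a number. With compound 1 and compound 2 also at limits, neither step to compound 3 can be read. The compounds shown leave open what concentration of any of the three harms the cells, and whether changing the amide aryl group alters it.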